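Heteroaryl variation at the para position of a bombesin receptor-3 agonist

The compounds below may be only part of what the source reports. "The series", "measured", "known", "first", "only" and "open" are said of these compounds alone.

Compounds measured so far:
compound 1 `CCC(C)(C)Cc1c[nH]c(CCc2ccc(-c3cccc(C)n3)cc2)n1`: 102 nM
compound 2 `CCC(C)(C)Cc1c[nH]c(CCc2ccc(-c3cnccn3)cc2)n1`: 100 nM
compound 3 `CCC(C)(C)Cc1c[nH]c(CCc2ccc(-c3cccc(N)n3)cc2)n1`: 97 nM

In a functional assay on HEK293 cells for agonist activity at Bombesin receptor subtype-3 (Homo sapiens), read by luminescence and calcium flux, with a stated time of 10 min (on this read-out higher numbers stand for an effect only at larger amounts of compound and lower numbers for an effect already at smaller amounts), compound 1 gives 102 nM, the largest of the three numbers, while compound 2 gives 100 nM and compound 3 gives 97 nM. The steps of a 1.0-fold lower number from compound 1 to compound 2 (0.01 log units; within the scatter) and a 1.1-fold lower number from compound 1 to compound 3 (0.02 log units; within the scatter) both lie within the scatter, as does a 1.0-fold lower number from compound 2 to compound 3 (0.01 log units; within the scatter). Compound 4 `CCC(C)(C)Cc1c[nH]c(CCc2ccc(-c3cccnc3C(=O)O)cc2)n1` has not yet been measured. It differs from compound 1 as follows: 2-carboxypyridin-3-yl in place of 6-methylpyridin-2-yl on an aromatic carbon. All three measured steps concern this same aromatic carbon, and none of them moved the number beyond the scatter, but none of them introduced a carboxy group, so the precedent is limited. Compound 4 is therefore expected to give about 200 nM, within a range of 50 nM to 1000 nM, meaning an expected step of a 2.0-fold higher number from compound 1 to compound 4 (0.29 log units; within the scatter).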

Compound 4, half-maximal effective concentration: 95 nM
Compound 4: middle estimate off by 2.1-fold (0.32 log units), on the high side, and the stated range covers the measured number.
By their numbers in this assay, from the lowest: compounds 4, 3, 2 and 1 (each within the scatter of the next).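

In this assay, 2-carboxypyridin-3-yl on this aromatic carbon, para to a large group, gives a 1.1-fold lower number from compound 1 to compound 4 (0.03 log units; within the scatter) and a 1.0-fold lower number from compound 3 to compound 4 (0.01 log units; within the scatter) and a 1.1-fold lower number from compound 2 to compound 4 (0.02 log units; within the scatter). Across these four compounds, the position therefore accommodates a carboxy-bearing ring as well as the rings without one, with no step beyond the scatter. Nothing available explains this flat result.

As far as these compounds go, whether a methyl ester or an amide in place of the carboxylic acid would also stay within the scatter remains open. So does whether a saturated ring such as piperidine at this carbon would do so.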